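The source may report more compounds than this note shows. Statements on the series, on what has been measured and on what is new or still open speak of the compounds shown alone.

Compound 1 `CC(C)Cn1nc(C(=O)N[C@H]2COc3ccccc3N(C)C2=S)nc1Cc1ccccc1`: > 100000 nM
Compound 2 `CN1C(=S)[C@@H](NC(=O)c2nc(Cc3ccccc3)n(CCCF)n2)COc2ccccc21`: > 100000 nM

Both entries are limits of the assay and not numbers. In a toxicity assay on HT-29 cells (Homo sapiens) for cytotoxicity (on this read-out lower numbers stand for higher toxicity in this test and higher numbers for lower toxicity in this test), compound 2 gives > 100000 nM, which is a limit. Compound 1 gives > 100000 nM, which is also a limit. Compound 2 therefore stands at the limit of > 100000 nM in this assay, at which 2 of the 2 values shown sit, and it offers no number from which to count a step.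

Compound 3 `COCCn1nc(C(=O)N[C@H]2COc3ccccc3N(C)C2=S)nc1Cc1ccccc1` keeps the shared core and changes only the chain on the aromatic nitrogen, where 3-fluoropropyl gives way to 2-methoxyethyl: methoxy in place of fluoromethyl on a saturated chain carbon, two bonds along the chain from an aromatic nitrogen. Among the compounds with values here, only one measured step bears on this change, and it concerns the same chain: a step that the two limits leave unreadable from compound 1 to compound 2. Within the data shown here, its size cannot be read, so it shows only that this change of chain left compound 2 at the same limit as compound 1.

On that evidence, no step beyond the scatter is expected in this assay, in either direction. The estimated change is a number no higher from compound 2 to compound 3 (the limit leaves the size open). The assay will most likely report only a limit again. For compound 3 the expected value is 100000 nM, with an estimated range from 50000 nM to 200000 nM.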

Compound 3, half-maximal cytotoxic concentration: > 100000 nM
Compound 3 was reported as a limit (the forecaster's own chance of this, stated with the estimate: 90%); the middle value lies on the limit itself.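

In this assay compound 3 gives > 100000 nM, which is a limit. No step can be read among compound 1, compound 2 and compound 3, which all stand together: the limit of > 100000 nM in this assay, at which 3 of the 3 values shown sit.

The compounds shown leave open whether their chains on the aromatic nitrogen differ at all in this read-out, and at what concentration any of the three would become toxic to these cells.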